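The compounds below may be only part of what the source reports. "The series", "measured", "known", "first", "only" and "open" are said of these compounds alone.

In a functional assay on CCRF-CEM cells (Homo sapiens) for cytotoxicity, in the presence of a further agent that is not named here (on this read-out higher numbers stand for weaker inhibition and lower numbers for stronger inhibition), compound 1 `Nc1nc(N)c(CCCN(Cc2ccc(NC(CCC(=O)O)C(=O)O)cc2)c2cc(F)c([N+](=O)[O-])cc2[N+](=O)[O-])c(O)n1` gives 43000 nM as its measured value. Compound 2 `Nc1nc(N)c(CCCN(Cc2ccc(NC(CCC(=O)O)C(=O)O)cc2)c2cc(F)cc(F)c2[N+](=O)[O-])c(O)n1` stands at a limit of the assay, with > 100000 nM as its entry. Compound 3 `Nc1nc(N)c(CCCN(Cc2ccc(NC(CCC(=O)O)C(=O)O)cc2)c2cc(F)ccc2[N+](=O)[O-])c(O)n1` differs from compound 2 through hydrogen in place of fluoro on an aromatic carbon with hydrogen in place of fluoro on an aromatic carbon, ortho to a nitro group. In this assay only a small step toward stronger inhibition is expected, perhaps none beyond the scatter, and the estimated at least 1.2-fold lower number from compound 2 to compound 3 (0.09 log units; that floor lies within the scatter) reflects this. Compound 3 is expected at 80000 nM with an estimated range of 25000 nM to 200000 nM for its value.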

Compound 3, half-maximal inhibitory concentration: > 100000 nM
Compound 3 was reported as a limit (the forecaster's own chance of this, stated with the estimate: 50%); middle value at least 1.2-fold (0.09 log units) from the limit.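

In this assay, among the compounds shown here, hydrogen in place of nitro gives the only readable step in this set, an at least 2.3-fold higher number from compound 1 to compound 3 (0.36 log units; beyond the scatter), so losing that nitro group goes with weaker inhibition, and the size printed is only a floor. The value of compound 3, > 100000 nM, is a limit of the assay and not a number. The step from fluoro to hydrogen ortho to a nitro group cannot be read, because both compounds on it sit at the limit: the limit of > 100000 nM in this assay, at which 2 of the 3 values shown sit.

Going by these compounds, whether fluoro at this position matters at all stays open. So does whether an amine or a carboxylic acid there would bring the number down within the measurable range.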